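The source may hold more compounds than are shown below. What is called first, only, known or untested is meant among the compounds shown, and "the series" means these compounds.

Compound 1, `COc1cccc(C(O)CCn2nc3c(Br)c(Br)c(Br)c(Br)c3n2)c1`, stands lowest of the three compounds measured in a functional assay on MCF7 cells (Homo sapiens) for antiproliferative activity, read by MTT assay, with a stated time of 24 h, tested at 25 uM (on this read-out higher numbers stand for a weaker effect at the one concentration tested and lower numbers for a stronger effect), where compound 1 gives 71%. Compound 2, `C[C@@H](O)CCn1nc2c(Br)c(Br)c(Br)c(Br)c2n1`, gives 105% in this assay, and compound 3, `C[C@H](O)CCn1nc2c(Br)c(Br)c(Br)c(Br)c2n1`, gives 102%. Among the compounds with values here, the only measured step between neighbours, a number 3 percentage points lower from compound 2 to compound 3 (within the scatter), rests on the fact that compounds 2 and 3 differ only in the configuration as drawn and so says nothing about a change of the aryl group.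

Compound 4, `OC(CCn1nc2c(Br)c(Br)c(Br)c(Br)c2n1)c1ccc(Cl)cc1`, differs from compound 1 by 4-chlorophenyl in place of 3-methoxyphenyl on a saturated chain carbon bound to an oxygen on a saturated carbon and a saturated chain carbon. No measured pair shows an exchange of one aromatic group for another, so the step from compound 1 to compound 4 has no direct precedent among these compounds; the account can only note that compound 1, the one aryl compound, sits apart from compounds 2 and 3 in the numbers shown.

Within the data shown here, with no comparable step available, compound 4 is expected to stay near compound 1, the expected step being a number 1 percentage points lower from compound 1 to compound 4 (within the scatter). On that basis compound 4 is estimated at 70% in this assay, with a range from 50% to 92%.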

Compound 4, a percentage reported as activity, at one concentration (the size of the read-out at that concentration, not a potency): 96%
Compound 4: the middle estimate sits 26 percentage points below what was measured; the whole stated range lies below it.
By their numbers in this assay, from the lowest: compound 1; then compounds 4, 3 and 2 (each within the scatter of the next).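

In this assay the exchange of 3-methoxyphenyl for 4-chlorophenyl on this saturated chain carbon brings a number 25 percentage points higher from compound 1 to compound 4 (beyond the scatter) and thus a weaker effect at the one concentration tested. Within the data shown here, the earlier compounds held only a change of configuration, so this is the first sign that the aryl group at this place matters and that the effect of compound 1 does not come with just any aryl group. Nothing in the available data explains this step.

The compounds shown leave open whether the step follows the methoxy group, the chlorine or the place each occupies on the ring, which 4-methoxyphenyl, 3-chlorophenyl or plain phenyl would help to separate. Also open, on these data alone, is how an aryl group carrying an amine or a carboxylic acid would read out here.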